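Sulfonamide spiro series: cytotoxicity limits and a methoxy analogue

The source may report more compounds than this note shows. Statements on the series, on what has been measured and on what is new or still open speak of the compounds shown alone.

Measured compounds in a functional assay on Huh-7 cells (Homo sapiens) for cytotoxicity, read by MTT assay, with a stated time of 72 h; a higher number here means that more compound is tolerated, a lower number that less compound is tolerated:
Compound 1 `Cc1ccc(S(=O)(=O)N2CCC3(CC2)OOC2(CCCCC2)OO3)cc1` reports only a limit, > 100 ug/mL.
Compound 2 `Cc1ccc(S(=O)(=O)N2CCC3(CC2)OOC2(CCCCCC2)OO3)cc1` reports only a limit, > 100 ug/mL.
Compound 3 `COc1ccc(S(=O)(=O)N2CCC3(CC2)OOC2(CCCCC2)OO3)cc1` reports only a limit, > 100 ug/mL.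

Compound 3 arises from compound 1 by methoxy in place of methyl on an aromatic carbon. The step that the two limits leave unreadable from compound 1 to compound 3 cannot be sized, because both values sit at the limit of > 100 ug/mL in this assay, at which 3 of the 3 values shown sit. The difference between the cores of compound 1 and compound 2 is not broken down here.

Compound 4 `COc1ccc(S(=O)(=O)N2CCC3(CC2)OOC2(CCCCCC2)OO3)cc1` is not yet measured in this assay. It arises from compound 2 by methoxy in place of methyl on an aromatic carbon, the same change as from compound 1 to compound 3, at the same kind of place.

The step that the limit leaves unreadable from compound 2 to compound 4 is expected to be small, resting on a step that the two limits leave unreadable from compound 1 to compound 3 and on the limit at the limit of > 100 ug/mL in this assay, at which 3 of the 3 values shown sit. Compound 4 is therefore estimated at 150 ug/mL in this assay, most probably again reported only as a limit.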

Compound 4, half-maximal cytotoxic concentration: > 100 ug/mL
Compound 4: no number, only a limit; the forecaster's own chance of this, stated with the estimate: 85%; the middle value lies beyond the limit too.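

No size can be read for the step from compound 2 to compound 4, because both report only a limit: the limit of > 100 ug/mL in this assay, at which 4 of the 4 values shown sit.

The compounds shown leave open how much compound is actually tolerated for any of the four, and whether methoxy in place of methyl makes any difference.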